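The compounds below may be only part of what the source reports. "The series", "measured", "known", "first", "only" and "open" are said of these compounds alone.

Measured so far:
compound 1 `[O-][S+](CCC(F)=C(F)F)c1ncc(-c2ccncc2)s1` — > 120000 nM
compound 2 `[O-][S+](CCC(F)=C(F)F)c1nccs1` — > 120000 nM
compound 3 `O=S(=O)(CCC(F)=C(F)F)c1ncc(-c2ccncc2)s1` — > 120000 nM

In a functional assay on SH-SY5Y cells (Homo sapiens) for cytotoxicity, read by MTT assay, with a stated time of 48 h (a higher number here means a weaker inhibitor, a lower number a stronger inhibitor), compound 1 gives only a limit, > 120000 nM. Compound 2 likewise gives only a limit, > 120000 nM. Compound 3 too gives only a limit, > 120000 nM. Compound 2 arises from compound 1 by hydrogen in place of pyridin-4-yl on an aromatic carbon, and the step that the two limits leave unreadable from compound 1 to compound 2 cannot be read, since both ends sit at a limit. How the core of compound 3 differs from that of compound 1 is not broken down here.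

Compound 4 `O=S(=O)(CCC(F)=C(F)F)c1nccs1` is not yet measured. It arises from compound 3 by hydrogen in place of pyridin-4-yl on an aromatic carbon. The place is described in the same terms as for compound 1 to compound 2, except that there the ring atom bears a group of 9 heavy atoms, here a large group; this is the same kind of change, not the same one.

For this assay the expectation is a step that the limit leaves unreadable from compound 3 to compound 4 beside a step that the two limits leave unreadable from compound 1 to compound 2. This rests on (the limit of > 120000 nM in this assay, at which 3 of the 3 values shown sit), since every measured value sits there. Compound 4 is expected at 150000 nM, with a range from 60000 nM to 400000 nM.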

Compound 4, half-maximal inhibitory concentration: > 120000 nM
Compound 4: no number, only a limit; the forecaster's own chance of this, stated with the estimate: 85%; the middle value lies beyond the limit too.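

In this assay compound 4 gives > 120000 nM, a limit and not a number. With compound 3 also at a limit, the step between compound 3 and compound 4 cannot be read: the limit of > 120000 nM in this assay, at which 4 of the 4 values shown sit.

The compounds shown leave open how far each lies from that limit, and whether pyridin-4-yl or the change at the core shifts the read-out at all.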